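Chloro to Trifluoromethyl: An Estimate for Compound 3

The compounds below may be only part of what the source reports. "The series", "measured", "known", "first", "only" and "open" are said of these compounds alone.

Measured compounds:
compound 1 `CC1CN(CCn2ccc3ccc(Br)cc32)CC(C)N1`: 26%
compound 2 `CN1CCCN(CCn2ccc3ccc(Cl)cc32)CC1`: 85%

In an assay on HEK293 cells for binding affinity to 5-hydroxytryptamine receptor 7 (Homo sapiens), read by radioligand binding, tested at 1 uM (on this read-out higher numbers stand for more inhibition at the one concentration tested (going by the name of the read-out) and lower numbers for less inhibition), compound 2 gives 85%, the highest of the two numbers seen so far. Its nearest neighbour, compound 1, sits far below it, a gap beyond the usual scatter, although the two compounds differ in more than one place, so the gap cannot be pinned on any single change.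

Compound 3 `CN1CCCN(CCn2ccc3ccc(C(F)(F)F)cc32)CC1` keeps the whole core of compound 2 and differs in one place: trifluoromethyl in place of chloro on an aromatic carbon. Within the data shown here, no measured pair isolates this exchange, so its size is unknown. Compound 3 is expected to give about 78%, with a range from 55% to 95%. The step of a number 7 percentage points lower from compound 2 to compound 3 (within the scatter) is expected to be small, within the scatter or a modest drop.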

Compound 3, a percentage reported as inhibition, at one concentration (the size of the read-out at that concentration, not a potency): 89%
Beside the measured number, compound 3's estimate is 11 percentage points below it; the measured number falls inside the stated range.
By their numbers in this assay, from the lowest: compound 1; then compounds 2 and 3 (each within the scatter of the next).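

Putting trifluoromethyl in place of chloro on this aromatic carbon gives a number 4 percentage points higher from compound 2 to compound 3 (within the scatter) in this assay and so leaves the two groups indistinguishable on this read-out. Among these compounds, this is the first exchange here that can be read at a single place, and it shows that on this core the position carries either group, with 1 heavy atom leaving and 4 entering, and the reading stays high. Because each compound was read at one concentration, the pair shows no difference in potency, only the same size of inhibition within the scatter.

On these data alone, whether the position also takes a group of another kind, such as an amine, a carboxylic acid or a longer chain, stays open. Nothing available explains why chloro and trifluoromethyl read alike here.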